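The source may hold more compounds than are shown below. What is called first, only, known or untested is meant among the compounds shown, and "the series" means these compounds.

For the measured compounds named here, compound 3 `CCCC(=O)Nc1ccc(S(=O)(=O)Oc2ccccc2C(C)C)cc1` gives 4900 nM in a functional assay on HT-29 cells (Homo sapiens) for antiproliferative activity, read by sulforhodamine B assay, with a stated time of 48 h (a lower number here means a stronger inhibitor, a higher number a weaker inhibitor), the lowest of the three numbers measured so far. Compound 2 `CCC(=O)Nc1ccc(S(=O)(=O)Oc2ccccc2I)cc1` gives 11000 nM in this assay, and compound 1 `CC(=O)Nc1ccc(S(=O)(=O)Oc2ccccc2I)cc1` gives 23000 nM. Compound 4 `CCCC(=O)Nc1ccc(S(=O)(=O)Oc2ccccc2I)cc1` has not yet been measured; it differs from compound 3 by iodo in place of isopropyl on an aromatic carbon. Going by the values given here, no measured step exchanges these two groups directly, so the pair of compound 1 and compound 2, both carrying iodo on the core of compound 1, is the only guide: a 2.1-fold lower number from compound 1 to compound 2 (0.32 log units; beyond the scatter) shows that lengthening the chain matters modestly there. Compound 4 extends that chain one step further on the same core, so its number is expected close to that of compound 3, a 1.2-fold higher number from compound 3 to compound 4 (0.09 log units; within the scatter), within the scatter. The estimate for compound 4 is 6000 nM, with a range from 2500 nM to 14000 nM.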

Compound 4, half-maximal inhibitory concentration: 11000 nM
Estimate against measurement, compound 4: 1.8-fold (0.26 log units) below; low and high end bracket the measured number.
By their numbers in this assay, from the lowest: compound 3; then compounds 2 and 4 (each within the scatter of the next); then compound 1.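

With the chain held fixed, the aromatic carbon ortho to a large group now has a direct reading in this assay: a 2.2-fold higher number from compound 3 to compound 4 (0.35 log units; beyond the scatter) for iodo in place of isopropyl. On the iodo core, the chain step does not carry on: no change at the digits printed from compound 2 to compound 4 (within the scatter), while a 2.1-fold lower number from compound 1 to compound 4 (0.32 log units; beyond the scatter) matches the earlier single step in size. No available evidence bears on the reason for these steps.

Open, from the compounds shown here alone, is whether methoxy or a carboxylic acid at this aromatic carbon would move the number beyond the range seen with iodo and isopropyl. Going by these compounds, a longer chain on the iodo core also remains open.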